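This account rests on a few compounds, and the source may have more. Where it says the series, first, only, none or still open, it means among the compounds named here.

Measured so far in a functional assay on HeLa cells for antagonist activity at 5-hydroxytryptamine receptor 6 (Homo sapiens), read by cAMP accumulation; a lower number here means a stronger inhibitor, a higher number a weaker inhibitor:
Compound 1, `CN1CCC(c2n[nH]c3ccc(S(=O)(=O)c4ccc5ccccc5c4)cc23)CC1`, gives 102 nM.
Compound 2, `CN1CCC(c2n[nH]c3ccc(S(=O)(=O)c4cccc(Cl)c4)cc23)CC1`, gives 754 nM.

Of the two numbers in this assay, compound 2 holds the higher one; compound 1 sits lower by a margin that lies beyond the usual scatter, so compound 1 is the stronger inhibitor of the pair. Compound 3, `CC(C)c1ccc(S(=O)(=O)c2ccc3[nH]nc(C4CCN(C)CC4)c3c2)cc1`, has not yet been measured. It differs from compound 2 in one place: 4-isopropylphenyl in place of 3-chlorophenyl on a sulfonyl sulfur. Within the data shown here, no measured pair shows this exact change, so its size is not known from the data. Compound 3 is expected to give a lower number than compound 2, a step of moderate size, a 2.5-fold lower number from compound 2 to compound 3 (0.40 log units; beyond the scatter), likely beyond the scatter but not reaching the value of compound 1. For compound 3 the estimate in this assay is 300 nM, with a range from 80 nM to 1200 nM.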

Compound 3, half-maximal inhibitory concentration: 108 nM
Compound 3: the middle estimate sits 2.8-fold (0.44 log units) above what was measured; measured number inside the range.
By their numbers in this assay, from the lowest: compounds 1 and 3 (each within the scatter of the next); then compound 2.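

In this assay, 4-isopropylphenyl in place of 3-chlorophenyl on a sulfonyl sulfur brings a 7.0-fold lower number from compound 2 to compound 3 (0.84 log units; beyond the scatter), so the number changes beyond the scatter even though both groups hold one six-membered aromatic ring of carbon only. Compound 3, at 108 nM, and compound 1, at 102 nM, lie within the scatter of each other, so the level of compound 1 at this position is also reached with a single-ring group. Nothing shown here accounts for the step.

The change swaps the substituent and its place on the ring together, so the compounds shown do not separate the two. As far as these compounds go, how 4-chlorophenyl or 3-isopropylphenyl would compare remains open, as does the effect of an amine or a carboxylic acid on that ring.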